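Methyl on the fused carbocyclic ring of the compound 2 core

The source may hold more compounds than are shown below. What is called first, only, known or untested is meant among the compounds shown, and "the series" means these compounds.

Measured so far:
- compound 1 `Cc1ccc2nc(Cl)c(/C=N/n3cc(-c4ccccc4)nc3N)cc2c1`: 8790 nM
- compound 2 `Nc1nc(-c2cccs2)cn1/N=C/c1cc2ccccc2nc1Cl`: 10300 nM

In a functional assay on DLD-1 cells (Homo sapiens) for cytotoxicity, read by MTT assay, with a stated time of 48 h (on this read-out higher numbers stand for weaker inhibition and lower numbers for stronger inhibition), compound 1 gives 8790 nM and compound 2 gives 10300 nM. The two numbers lie within the usual scatter of each other, so no ranking between compound 2 and compound 1 is supported by this assay; the pair also differs in two places at once, so neither change can be read out on its own.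

Compound 3 `Cc1ccc2nc(Cl)c(/C=N/n3cc(-c4cccs4)nc3N)cc2c1` is not yet measured. Its change from compound 2 is methyl in place of hydrogen on an aromatic carbon. Within the data shown here, no measured pair isolates this change, and the only two numbers so far are indistinguishable within the scatter. The step from compound 2 to compound 3 in this assay is therefore expected to be none beyond the scatter, in either direction, as a 1.1-fold lower number from compound 2 to compound 3 (0.04 log units; within the scatter). Compound 3 is expected to give about 9500 nM in this assay, between 4000 nM and 22000 nM.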

Compound 3, half-maximal inhibitory concentration: 8990 nM
The estimate for compound 3 lay 1.1-fold (0.02 log units) above the measured number; the range from low to high includes it.
By their numbers in this assay, from the lowest: compounds 1, 3 and 2 (each within the scatter of the next).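

In this assay, methyl in place of hydrogen on an aromatic carbon of the fused system gives a 1.1-fold lower number from compound 2 to compound 3 (0.06 log units; within the scatter) and is now isolated in a single pair, so on this read-out methyl at this position is not told apart from hydrogen. Thiophen-2-yl in place of phenyl, also isolated now on the methyl-bearing core, gives a 1.0-fold higher number from compound 1 to compound 3 (0.01 log units; within the scatter) and likewise separates neither group from the other. Nothing at hand bears on the reason for either result.

On these data alone, whether ethyl, methoxy or an amine on this same aromatic carbon would move the number beyond the scatter stays open. Also open, as far as these compounds go, is whether phenyl and thiophen-2-yl remain indistinguishable on the core without methyl, as compound 2 has no partner carrying phenyl on that core.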